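Two Measured Thiazole Acids and One Untested Analogue

The compounds below may be only part of what the source reports. "The series", "measured", "known", "first", "only" and "open" are said of these compounds alone.

Measured compounds:
- compound 1, `Nc1nc(-c2ccc(Cl)cc2)c(CC(=O)O)s1`, gives 50%
- compound 2, `NS(=O)(=O)c1ccc(-c2nc(C(c3ccc(F)cc3)c3ccc(F)cc3)sc2CC(=O)O)cc1`, gives 80%

Both compounds were tested in an in vitro functional assay on HEK285-7 cells for antagonist activity at prostaglandin D2 receptor 2 (Homo sapiens), read by BRET and beta-arrestin recruitment; a lower number here means a smaller maximal response, a higher number a larger maximal response. Compound 1 gives 50% in this assay, and compound 2 gives 80%. Of the two numbers, compound 2 is the higher, and the gap to compound 1 is beyond the usual scatter of repeated measurements, so compound 2 reaches the larger maximal response of the pair.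

Compound 3, `CN(C)c1cc(-c2nc(C(c3ccc(F)cc3)c3ccc(F)cc3)sc2CC(=O)O)ccn1`, has not yet been measured. It differs from compound 2 in one place: 2-(dimethylamino)pyridin-4-yl in place of 4-sulfamoylphenyl on an aromatic carbon. The shared core, the carboxymethyl group and the large group that carries two fluorophenyl rings are kept.

Within the data shown here, no step between two measured compounds with a change of this kind is available, so the expectation rests on the value of compound 2 alone. Compound 3 is expected to stay close to compound 2, with a step of a number 8 percentage points lower from compound 2 to compound 3 (within the scatter) that lies within or only slightly beyond the scatter. The estimate for compound 3 in this assay is 72%, with a range from 45% to 95%.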

Compound 3, largest response reached (reported as efficacy), in percent of the reference or control that the assay uses: 80%
The estimate for compound 3 lay 8 percentage points below the measured number, and the stated range covers the measured number.
By their numbers in this assay, from the lowest: compound 1; then compounds 2 and 3 (each within the scatter of the next).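

In this assay, putting 2-(dimethylamino)pyridin-4-yl in place of 4-sulfamoylphenyl on an aromatic carbon of the five-membered ring gives no change at the digits printed from compound 2 to compound 3 (within the scatter). Among these compounds, this is the first pair here that differs in one place, and it shows that the maximal response at this position does not depend on the sulfamoyl group: the entering group has a nitrogen in its aromatic ring, a dimethylamino group instead of the sulfur and oxygen atoms, and no hydrogen-bond donor, yet the reading stays level. No measurement at hand explains why the response holds across this exchange.

Among the compounds shown here, the pair tests only one exchange, so it remains open whether a plain phenyl ring, or a phenyl ring bearing a carboxylic acid, would also hold the response at this position. Compound 1 differs from compound 2 and compound 3 in more than one place, so the compounds shown do not tell how the amine on its core, its 4-chlorophenyl ring or the large group with two fluorophenyl rings each contributes to the response.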